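This account rests on a few compounds, and the source may have more. Where it says the series, first, only, none or still open, it means among the compounds named here.

Of the compounds shown here, three have so far been measured in an assay on isolated protein for inhibition of aldehyde dehydrogenase 1A1 (Homo sapiens), read by spectrophotometry, tested at 10 uM; a lower number here means less inhibition, a higher number more inhibition at the concentration tested (going by the name of the read-out). Compound 1 `O=C(C1CC1)N1CCN(Cc2nc3ccccc3n2Cc2ccccc2F)CC1` gives 40.7%, which is the second highest of the three numbers. Compound 2 `CC(C)CCn1c(OC2CCN(C(=O)c3ccco3)CC2)nc2ccccc21` gives 30.8%, a number close to that of compound 1 and within the usual scatter, so the two cannot be told apart. Compound 3 `CC(=O)N1CCN(Cc2nc3ccccc3n2Cc2cccc(C)c2)CC1` gives 70.3%, a number clearly higher than that of compound 1 and beyond the scatter. No two of these three compounds differ in just one place, so none of the gaps between them can be tied to a single structural change.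

Compound 4 `O=C(C1CC1)N1CCN(Cc2nc3ccccc3n2Cc2cccc(F)c2)CC1` has not yet been measured. It differs from compound 1 in one place: 3-fluorophenyl in place of 2-fluorophenyl on a saturated chain carbon bound to an aromatic nitrogen. Within the data shown here, no measured pair shows this change on its own, so nothing here tells how large its effect is. The step from compound 1 to compound 4 is expected to be small, a number 7.3 percentage points higher from compound 1 to compound 4 (within the scatter), upward if anything and most likely within the scatter. Compound 4 is estimated to give 48% in this assay, with a range from 28% to 68%.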

Compound 4, a percentage reported as inhibition, at one concentration (the size of the read-out at that concentration, not a potency): 27.2%
Compound 4: middle estimate off by 20.8 percentage points, on the high side; measured number below the stated range.
By their numbers in this assay, from the lowest: compounds 4, 2 and 1 (each within the scatter of the next, the first and the last beyond it); then compound 3.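

In this assay, 3-fluorophenyl in place of 2-fluorophenyl on a saturated chain carbon bound to an aromatic nitrogen gives a number 13.5 percentage points lower from compound 1 to compound 4 (beyond the scatter). Among these compounds, this is the first comparison here that ties a gap to a single structural change, and it shows that this place on the core of compound 1 responds to where the fluorine stands on the phenyl ring, even though the two compounds hold the same atoms. Nothing available accounts for the drop, so the result stands as an observation only.

The compounds shown leave open how a plain benzyl group or a 4-fluorobenzyl group would fare at this place. They also leave open whether the step from this single pair would hold with a different acyl group on the piperazine-side nitrogen, such as a benzoyl group.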